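Swapping a Nitro Group for Chlorine on a Shared Core

This account rests on a few compounds, and the source may have more. Where it says the series, first, only, none or still open, it means among the compounds named here.

Compound 1 `O=[N+]([O-])c1cccc(Nc2nnc(-c3c[nH]c4ccccc34)o2)c1` carries a nitro group on the aromatic ring that hangs from the shared core. Going by the values given here, in a functional assay on HeLa cells (Homo sapiens) for inhibition, read by MTT assay, with a stated time of 72 h (on this read-out lower numbers stand for stronger inhibition and higher numbers for weaker inhibition), compound 1 gives 15100 nM, the highest of the two numbers measured so far, which means the weaker inhibition of the pair. Its companion compound 2 `O=[N+]([O-])c1ccc(Nc2nnc(-c3c[nH]c4ccccc34)o2)cc1` carries the same nitro group placed differently on that ring; in this assay compound 2 gives 1760 nM, a number lower by a margin beyond the usual scatter. Compound 3 `Clc1cccc(Nc2nnc(-c3c[nH]c4ccccc34)o2)c1` has not yet been measured. It differs from compound 1 by chloro in place of nitro on an aromatic carbon. Among the compounds with values here, no measured pair shows what this exchange does to the numbers, so the direction of the coming step is open. Because compound 1 stands at 15100 nM, compound 3 is expected to land nearby, with a step of a 1.5-fold lower number from compound 1 to compound 3 (0.18 log units; within the scatter) that may well stay within the scatter. The estimate for compound 3 is 10000 nM, with a range from 3000 nM to 40000 nM.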

Compound 3, half-maximal inhibitory concentration: 5600 nM
For compound 3 the middle estimate is 1.8-fold (0.25 log units) above the measured one; low and high end bracket the measured number.
By their numbers in this assay, from the lowest: compound 2; then compound 3; then compound 1.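

At this place on the ring, meta to a large group, the nitro group can be given up without losing inhibition: in this assay, chloro in place of nitro gives a 2.7-fold lower number from compound 1 to compound 3 (0.43 log units; beyond the scatter), a modest step but one beyond the usual scatter. Going by these compounds alone, compound 1 and compound 2 differ only in where the nitro group sits, so this is the first measured change of the group itself. The hydrogen-bond acceptors of the nitro group are not needed for this level of inhibition, as the chloro group in compound 3 has none.

Nothing measured here explains why the number falls with this exchange. Going by these compounds, it remains open whether an amine or a methyl group at this place would lower the number further, and what chloro would do where compound 2 carries its nitro group.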